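The compounds below may be only part of what the source reports. "The series", "measured", "known", "first", "only" and "open" are said of these compounds alone.

Compound 1 `O=C(OCCCc1ccccc1)c1cc(-n2cc(-c3cccc(O)c3)nn2)ccc1O`: 11%
Compound 2 `COC(=O)c1cc(-n2cc(-c3cc(OC)cc(OC)c3)nn2)ccc1O`: 3%
Compound 3 `COc1cc(OC)cc(-c2cn(-c3ccc(O)c(C(=O)O)c3)nn2)c1`: 2%

In a functional assay on HCT-116 cells (Homo sapiens) for inhibition, read by MTT assay, with a stated time of 2 days, tested at 10 uM (a lower number here means less inhibition, a higher number more inhibition at the concentration tested (going by the name of the read-out)), compound 3 gives 2%, the lowest of the three numbers, yet both neighbours lie within the scatter of it: compound 2 shows 3% and compound 1 shows 11%. Compound 4 `COc1cc(OC)cc(-c2cn(-c3ccc(O)c(C(=O)Nc4cccc(C(F)(F)F)c4)c3)nn2)c1` has not yet been measured. It differs from compound 3 by (3-(trifluoromethyl)phenyl)amino in place of hydroxy on a carbonyl carbon.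

Going by the values given here, only one measured step touches the same carbonyl carbon, a number 1 percentage points lower from compound 2 to compound 3 (within the scatter), and that change was small, within the scatter. Among the compounds with values here, no measured step swaps a hydroxy for an amino group on this carbonyl, so the bearing of that swap is unknown. Compound 1, which carries the largest group on this carbonyl among the three, sits within the scatter of the other two, so a larger group there has not yet moved this assay beyond the scatter.

Compound 4 is therefore expected to stay near compound 3, at an estimated 8%, between 0% and 25%, an expected step of a number 6 percentage points higher from compound 3 to compound 4 (within the scatter).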

Compound 4, a percentage reported as inhibition, at one concentration (the size of the read-out at that concentration, not a potency): 62%
The estimate for compound 4 lay 54 percentage points below the measured number; the whole stated range lies below it.
By their numbers in this assay, from the lowest: compounds 3, 2 and 1 (each within the scatter of the next); then compound 4.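

In this assay, the carbonyl carbon proves able to carry a change that moves the number far beyond the scatter: (3-(trifluoromethyl)phenyl)amino in place of hydroxy gives a number 60 percentage points higher from compound 3 to compound 4 (beyond the scatter) and the same group in place of methoxy gives a number 59 percentage points higher from compound 2 to compound 4 (beyond the scatter) on the same core. The earlier swap at this carbon, hydrogen in place of methyl on the oxygen, gave only a number 1 percentage points lower from compound 2 to compound 3 (within the scatter) and so showed no such sensitivity. No supporting measurement is available to explain the size of this rise.

The compounds shown leave open whether the rise needs the whole entering group: a plain phenylamino group, without trifluoromethyl, or a small methylamino group on this carbonyl would separate the contributions of its parts. As far as these compounds go, each number is also a reading at one concentration, so how potent compound 4 is remains open.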